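Trifluoromethyl on the benzyl ring of a chromene hydroxyurea

The source may report more compounds than this note shows. Statements on the series, on what has been measured and on what is new or still open speak of the compounds shown alone.

Compound 1 `CN(O)C(=O)C1=Cc2ccccc2OC1`: in an assay (Cavia porcellus) for inhibition of Polyunsaturated fatty acid 5-lipoxygenase (Homo sapiens) (a higher number here means a weaker inhibitor, a lower number a stronger inhibitor), compound 1 gives 830 nM.
Compound 2 `NC(=O)N(O)CC1=Cc2cc(OCc3ccccc3)ccc2OC1`: in this assay compound 2 gives 440 nM.

Only these two compounds have been measured, and they differ in more than one place, so no single structural step can be read from them. Compound 2 has the lowest of the two numbers, but its nearest neighbour, compound 1, lies within the usual scatter of the measurement, so the two cannot be ranked against each other.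

Compound 3 `NC(=O)N(O)CC1=Cc2cc(OCc3ccc(C(F)(F)F)cc3)ccc2OC1` is the next compound to be measured. It differs from compound 2 by trifluoromethyl in place of hydrogen on an aromatic carbon. With no comparable change among the measured compounds, the size of the effect is open; a change of no more than the scatter, in either direction, is the most defensible expectation. For compound 3, the expected step is a 1.3-fold lower number from compound 2 to compound 3 (0.10 log units; within the scatter). Compound 3 is therefore estimated at 350 nM, within a range of 120 nM to 1000 nM.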

Compound 3, half-maximal inhibitory concentration: 430 nM
Compound 3: the middle estimate sits 1.2-fold (0.09 log units) below what was measured, within the range that was stated.
By their numbers in this assay, from the lowest: compounds 3, 2 and 1 (each within the scatter of the next).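

In this assay the step is a 1.0-fold lower number from compound 2 to compound 3 (0.01 log units; within the scatter) and so compounds 2 and 3 cannot be told apart. Going by these compounds alone, this is the first comparison that differs in one place only, which the earlier pair could not offer. It shows that on this aromatic carbon, para to a large group, trifluoromethyl with its 4 heavy atoms can stand in place of hydrogen while the number stays within the scatter. Nothing measured here bears on why this is so.

The compounds shown leave open whether this position would tolerate other groups in the same way, such as an amine, a carboxylic acid or a methoxy group. A single step also cannot say whether trifluoromethyl would behave alike on the other carbons of this ring.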